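The source may hold more compounds than are shown below. What is called first, only, known or untested is meant among the compounds shown, and "the series" means these compounds.

Measured compounds:
- compound 1 `Cc1nc(-c2ccccc2)sc1COc1ccc(S(=O)(=O)CC(=O)O)cc1`, in a functional assay on CHO cells for agonist activity at Free fatty acid receptor 1 (Homo sapiens), read by FLIPR and calcium flux (on this read-out higher numbers stand for an effect only at larger amounts of compound and lower numbers for an effect already at smaller amounts), compound 1 gives 331 nM
- compound 2 `Cc1cccc(-c2nc(C)c(COc3ccc(S(=O)(=O)CC(=O)O)cc3)s2)c1`, in this assay compound 2 gives 214 nM
- compound 3 `Cc1noc(C)c1-c1cccc(COc2ccc(S(=O)(=O)CC(=O)O)cc2)c1`, in this assay compound 3 gives 269 nM

Compound 1 and compound 2 share a core and differ in one place: methyl in place of hydrogen on an aromatic carbon. The step this made in this assay was a 1.5-fold lower number from compound 1 to compound 2 (0.19 log units; within the scatter), so the two values do not separate from each other.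

Compound 3 carries a different core; the difference between the two cores of compound 1 and compound 3 is not broken down here. Its value in this assay lies close to that of compound 1 and that of compound 2, with all three within the scatter of one another.

Compound 4 `Cc1noc(C)c1-c1cccc(COc2ccc(S(=O)(=O)CC(=O)O)cc2)c1C` is not yet measured. It arises from compound 3 by the same kind of change that led from compound 1 to compound 2: methyl in place of hydrogen on an aromatic carbon. The surroundings differ, though: in the pair from compound 1 to compound 2 the methyl enters meta to a large group, whereas in compound 4 it enters ortho to a 3,5-dimethyl-1,2-oxazol-4-yl group and ortho to a large group, so the two changes are of the same kind but not the same.

Going by the values given here, with only one earlier example of the change, which gave a step within the scatter from compound 1 to compound 2, compound 4 is expected to show a step of a 1.2-fold lower number from compound 3 to compound 4 (0.09 log units; within the scatter) in this assay, again within the scatter. Compound 4 is therefore estimated at 220 nM, in a range from 90 nM to 550 nM.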

Compound 4, half-maximal effective concentration: 363 nM
Compound 4: the middle estimate sits 1.7-fold (0.22 log units) below what was measured; measured number inside the range.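

In this assay, a methyl in place of hydrogen on the aromatic carbon ortho to a 3,5-dimethyl-1,2-oxazol-4-yl group and ortho to a large group gave a 1.3-fold higher number from compound 3 to compound 4 (0.13 log units; within the scatter), so these two values do not separate from each other. Set beside the earlier example of the same change, the step on this second core gives no sign that the change behaves differently from one core to the other: the same change on two cores in this assay, a 1.5-fold lower number (0.19 log units; within the scatter) from compound 1 to compound 2 and a 1.3-fold higher number (0.13 log units; within the scatter) from compound 3 to compound 4, 2.1-fold (0.32 log units) apart, within the scatter of two such steps. Going by these compounds alone, this shows only that on these two cores, and in these two different surroundings, the methyl left the number within the scatter; it does not show that the methyl is without effect in general or that the same would hold on a further core, and the opposite directions of the two steps carry no meaning at this size.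

The compounds shown leave open whether another small group on the same aromatic carbon, such as fluorine, chlorine or methoxy, or a longer chain such as ethyl, would produce a step beyond the scatter. They also leave open how the series would respond if an amide stood in place of the carboxylic acid.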